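Swapping hydroxy for carboxy on compound 1

The source may report more compounds than this note shows. Statements on the series, on what has been measured and on what is new or still open speak of the compounds shown alone.

In a functional assay on HepG2 cells (Homo sapiens) for cytotoxicity, read by sulforhodamine B assay, with a stated time of 24 h (on this read-out higher numbers stand for weaker inhibition and lower numbers for stronger inhibition), compound 1 (`O=C1Nc2ccc(S(=O)(=O)N3CCOCC3)cc2/C1=N/c1ccc(O)cc1`) gives 10400 nM while compound 2 (`COc1ccc(-c2c(C#N)c(N)n(/N=C3\C(=O)Nc4ccc(S(=O)(=O)N5CCOCC5)cc43)c(=O)c2C#N)cc1`) gives 15000 nM and compound 3 (`O=C1Nc2ccc(S(=O)(=O)N3CCOCC3)cc2/C1=N/c1ccc(/N=C2\C(=O)Nc3ccc(S(=O)(=O)N4CCOCC4)cc32)cc1`) gives 8840 nM as half-maximal inhibitory concentrations. Repeated measurements of this kind always scatter somewhat, and these three numbers all lie within that scatter of one another, so compound 1 cannot be ranked against the other two.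

Compound 4 (`O=C1Nc2ccc(S(=O)(=O)N3CCOCC3)cc2/C1=N/c1ccc(C(=O)O)cc1`) has not been measured yet. It keeps the core of compound 1 and puts carboxy in place of hydroxy on an aromatic carbon, para to a large group (carboxy in place of hydroxy on an aromatic carbon) so that 4-hydroxyphenyl becomes 4-carboxyphenyl. Among the measured compounds shown here, no measured pair shows a single change like this one, so the expectation rests only on how closely the three numbers sit, with compound 1 at 10400 nM as the starting point. In this assay the expected change (a 1.2-fold higher number from compound 1 to compound 4 (0.06 log units; within the scatter)) is none beyond the scatter, with no firm direction. Compound 4 is estimated at 12000 nM with an expected range of 5000 nM to 28000 nM around that figure.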

Compound 4, half-maximal inhibitory concentration: 23100 nM
Compound 4: the middle estimate sits 1.9-fold (0.28 log units) below what was measured; the range from low to high includes it.
By their numbers in this assay, from the lowest: compounds 3, 1, 2 and 4 (each within the scatter of the next, the first and the last beyond it).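

In this assay, carboxy in place of hydroxy on an aromatic carbon, para to a large group, gives a 2.2-fold higher number from compound 1 to compound 4 (0.35 log units; beyond the scatter), which is a modest move towards weaker inhibition. Among the compounds shown here, the earlier compounds could not show this, since no two of them differed in one place only, so this is the first sign that the group at this position can change the read-out. It remains a single pair, so it gives the direction of this one swap and no general trend.

Open, going by these compounds, is whether another group at this position, such as an amine or a fluorine atom, would leave the number close to that of compound 1 or shift it further. No measurement shown speaks to what lies behind the step.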